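The source may hold more compounds than are shown below. What is called first, only, known or untested is meant among the compounds shown, and "the series" means these compounds.

Going by the values given here, compound 2, whose structure is `COC(=O)c1c(C(F)(F)F)[n+]([O-])c2ccc(C)cc2[n+]1[O-]`, stands at the lower of the two numbers measured so far in an ADME assay on J774 cells (Mus musculus) for cytotoxicity, read by MTT assay, with a stated time of 48 h; a lower number here means a stronger inhibitor, a higher number a weaker inhibitor. In that assay compound 2 gives 4000 nM, while compound 1, whose structure is `CCOC(=O)c1c(C(F)(F)F)[n+]([O-])c2ccc(C)cc2[n+]1[O-]`, gives 7000 nM. Among the compounds with values here, the one step measured so far, a 1.8-fold lower number from compound 1 to compound 2 (0.24 log units; within the scatter), is small enough to sit inside the usual scatter, so the two compounds cannot be told apart on these numbers. Compound 3, whose structure is `COC(=O)c1c(C(F)(F)F)[n+]([O-])c2ccc(F)cc2[n+]1[O-]`, differs from compound 2 by fluoro in place of methyl on an aromatic carbon. No measured step bears on this change: the step from compound 1 to compound 2 alters a different part of the molecule, and nothing shown here tells how exchanging one small group for another on the aromatic ring affects the read-out. With no guide, the sensible expectation is that compound 3 stays close to compound 2, with the step of no change at the digits printed from compound 2 to compound 3 (within the scatter) expected to be no larger than the scatter. Compound 3 is therefore estimated at 4000 nM in this assay, with a likely range from 1500 nM to 11000 nM.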

Compound 3, half-maximal inhibitory concentration: 2500 nM
Compound 3: middle estimate off by 1.6-fold (0.20 log units), on the high side; the range from low to high includes it.
By their numbers in this assay, from the lowest: compounds 3, 2 and 1 (each within the scatter of the next, the first and the last beyond it).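

In this assay, exchanging methyl for fluoro on this aromatic carbon gives a 1.6-fold lower number from compound 2 to compound 3 (0.20 log units; within the scatter), so compound 2 and compound 3 cannot be told apart on these numbers. The earlier step changed only the chain on the oxygen next to the carbonyl group, whereas this one gives the first reading from the six-membered aromatic ring, and it shows that this single exchange at this carbon leaves the read-out inside the usual scatter. The single-atom swap therefore produces no step that can be distinguished from repeat-measurement noise, and no measured information is available here to explain the result.

The compounds shown leave open whether a larger change on this aromatic carbon, such as chloro, methoxy, an amine or a plain hydrogen, would move the number beyond the scatter, since methyl and fluoro are the only groups seen there so far. They also leave open whether fluoro in place of methyl would give a similar result with the ethyl group of compound 1 or a longer chain on the oxygen next to the carbonyl group.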